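This account rests on a few compounds, and the source may have more. Where it says the series, first, only, none or still open, it means among the compounds named here.

Working notes on the series. Compound 1 `O=C(CN1CCN(c2nnc(Cc3ccncc3)c3ccccc23)CC1)Nc1cccc(Br)c1` in a functional assay on A549 cells (Homo sapiens) for cytotoxicity, read by MTT assay, with a stated time of 72 h (a lower number here means a stronger inhibitor, a higher number a weaker inhibitor), gives 1530 nM. Going by the values given here, compound 2 `O=C(CN1CCN(c2nnc(Cc3ccncc3)c3ccccc23)CC1)Nc1ccc(F)c(C(F)(F)F)c1` gives 16000 nM; the step of a 10-fold higher number from compound 1 to compound 2 (1.02 log units; beyond the scatter) is the only measured step in the set and concerns the amide-side aryl group. Compound 3 `Cc1ccccc1NC(=O)CN1CCN(c2nnc(Cc3ccccc3)c3ccccc23)CC1` in this assay is recorded as "not active" (no number reported), without a half-maximal inhibitory concentration; no number stands for it, so it marks the weak end of what is shown. Compound 4 `Cc1ccccc1NC(=O)CN1CCN(c2nnc(Cc3ccncc3)c3ccccc23)CC1` differs from compound 3 by pyridin-4-yl in place of phenyl on a saturated chain carbon bound to an aromatic carbon. Among the compounds with values here, no measured step bears on this change, and the step from compound 1 to compound 2 cannot be carried over. Compounds 1 and 2 carry the entering group and give numbers; compound 4 is therefore expected to return a measurable value, estimated at 6000 nM with a range from 1200 nM to 30000 nM.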

Compound 4, half-maximal inhibitory concentration: 43100 nM
Estimate against measurement, compound 4: 7.2-fold (0.86 log units) below; the measured number lies above the stated range.
By their numbers in this assay, from the lowest: compound 1; then compound 2; then compound 4.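

Pyridin-4-yl in place of phenyl on a saturated chain carbon bound to an aromatic carbon separates compound 4 (43100 nM) from the "not active" compound 3 in this assay, although the size of that step cannot be read. With pyridin-4-yl held, 2-methylphenyl on an amide-type nitrogen gives the highest number of the three aryl groups, with a 2.7-fold higher number from compound 2 to compound 4 (0.43 log units; beyond the scatter) and a 28-fold higher number from compound 1 to compound 4 (1.45 log units; beyond the scatter) as the steps. Nothing at hand explains these differences. Open, as far as these compounds go, is whether a pyridin-3-yl or a piperidin-4-yl group at this place would also give a number, and whether phenyl there would still do so alongside 3-bromophenyl.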